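The compounds below may be only part of what the source reports. "The series", "measured", "known", "first", "only" and "open" are said of these compounds alone.

Going by the values given here, compound 1 `O=C1/C(=C/c2ccc(F)cc2)Cc2cc(O)ccc21` stands lowest of the two numbers so far in an assay on isolated protein for inhibition of Amine oxidase [flavin-containing] B (Homo sapiens), read by fluorescence and spectrophotometry, with a stated time of 20 min (a lower number here means a stronger inhibitor, a higher number a weaker inhibitor), where compound 1 gives 47 nM. The nearest neighbour, compound 2 `COc1cccc(/C=C2\Cc3cc(O)ccc3C2=O)c1`, gives 471 nM in this assay, a gap well beyond the scatter. Compound 3 `CC(C)c1ccc(/C=C2\Cc3cc(O)ccc3C2=O)cc1` is not yet measured; it differs from compound 1 by isopropyl in place of fluoro on an aromatic carbon. Among the compounds with values here, no step between measured compounds covers this exchange, so the expectation rests on compound 1 alone. The expected step from compound 1 to compound 3 in this assay is a 1.4-fold higher number from compound 1 to compound 3 (0.14 log units; within the scatter), modest and not clearly beyond the scatter. Compound 3 is accordingly estimated at 65 nM, within 15 nM to 280 nM.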

Compound 3, half-maximal inhibitory concentration: 215 nM
Compound 3: middle estimate off by 3.3-fold (0.52 log units), on the low side; measured number inside the range.
By their numbers in this assay, from the lowest: compound 1; then compound 3; then compound 2.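

On the aromatic carbon para to a large group, the number in this assay responds to the substituent: isopropyl in place of fluoro gives a 4.6-fold higher number from compound 1 to compound 3 (0.66 log units; beyond the scatter). This position is therefore not indifferent to the exchange, although compound 3 remains an inhibitor in the measured range. Nothing measured here bears on the reason for this step. From the compounds shown here alone, how an amine or a carboxylic acid on this carbon would read in this assay remains open. Also open, going by these compounds, is whether a longer chain there would continue the direction set by isopropyl.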